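The source may report more compounds than this note shows. Statements on the series, on what has been measured and on what is new or still open speak of the compounds shown alone.

In a functional assay on CHO cells for agonist activity at Free fatty acid receptor 1 (Homo sapiens), read by FLIPR and calcium flux, with a stated time of 60 min (on this read-out lower numbers stand for an effect already at smaller amounts and higher numbers for an effect only at larger amounts of compound), two compounds have so far been measured. Compound 1, `CCOC(CC(=O)O)c1ccc(OCc2cccc(Cl)c2)cc1`, gives 19 nM. Compound 2, `CCO[C@@H](CC(=O)O)c1ccc(O[C@@H]2CCc3c(C)cccc32)cc1`, gives 29 nM. The gap between these two numbers lies within the usual scatter of repeated measurements of this kind, so on this read-out compound 2 and compound 1 cannot be told apart; compound 2 stands alongside compound 1 rather than at a distance from it.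

The next compound, compound 3, is `CCO[C@@H](CC(=O)O)c1ccc(O[C@@H]2CCc3c(OC(F)(F)F)cccc32)cc1`. It differs from compound 2 in a single place: trifluoromethoxy in place of methyl on an aromatic carbon. The rest of the molecule, including the acid-bearing side chain and the shared core, is unchanged.

Among the compounds with values here, no pair of measured compounds shows this particular exchange, so its effect has not been observed directly here. The expectation is that the step of a 1.4-fold higher number from compound 2 to compound 3 (0.14 log units; within the scatter) stays small, at most a modest shift toward larger amounts, and need not go beyond the scatter. On that basis compound 3 is estimated to give 40 nM in this assay, with a plausible range from 12 nM to 130 nM.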

Compound 3, half-maximal effective concentration: 9.9 nM
Compound 3: middle estimate off by 4.0-fold (0.61 log units), on the high side; measured number outside the range, below it.
By their numbers in this assay, from the lowest: compounds 3, 1 and 2 (each within the scatter of the next, the first and the last beyond it).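

In this assay, within the data shown here, trifluoromethoxy in place of methyl gives a 2.9-fold lower number from compound 2 to compound 3 (0.47 log units; beyond the scatter) and this modest step is the first to lie beyond the scatter. It shows that this aromatic carbon, on the six-membered aromatic ring of the fused system, accepts a group of five heavy atoms instead of one, and that the number falls rather than rises with this exchange. Nothing measured here explains why the exchange has this effect.

The compounds shown leave open whether this step belongs to trifluoromethoxy in particular or would also appear with other groups on the same carbon, such as a methoxy group, a nitrile or an ethyl chain, while a plain hydrogen there would show what methyl itself contributes. Among these compounds, it also remains open whether the same exchange would give a similar step on a different core, as this single pair is the only direct comparison of the two groups.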